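Swapping a ureido group for an acetamido group

The source may report more compounds than this note shows. Statements on the series, on what has been measured and on what is new or still open speak of the compounds shown alone.

Compound 1 `CC(C)c1n[nH]c2c(NCc3ccc(-c4ccccn4)cc3)nc(SC(C)C(C)O)nc12` gives 190 nM in a functional assay on HT cells (Homo sapiens) for antiproliferative activity, read by fluorescence, with a stated time of 72 h; a higher number here means a weaker inhibitor of growth, a lower number a stronger inhibitor of growth.
Compound 2 `CC(C)c1n[nH]c2c(NCc3ccc(-c4ccccn4)cc3)nc(SCCNC(=N)N)nc12` gives 390 nM.
Compound 3 `CC(C)c1n[nH]c2c(NCc3ccc(-c4ccccn4)cc3)nc(SCCNC(N)=O)nc12` gives 240 nM.

Compound 3 has the second highest of the three numbers, and both of its neighbours lie within the scatter: a 1.3-fold higher number from compound 1 to compound 3 (0.10 log units; within the scatter), and a 1.6-fold lower number from compound 2 to compound 3 (0.21 log units; within the scatter). Within the data shown here, only the group on the sulfur varies across these three compounds, and the sole step beyond the scatter is a 2.1-fold higher number from compound 1 to compound 2 (0.31 log units; beyond the scatter), a modest one.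

Compound 4 `CC(=O)NCCSc1nc(NCc2ccc(-c3ccccn3)cc2)c2[nH]nc(C(C)C)c2n1` differs from compound 3 at the far end of that chain: methyl in place of amino on a carbonyl carbon. The step that bears most closely on this change, from a guanidine-type end to a urea end, stayed within the scatter, so no step beyond the scatter is expected in this assay now. Compound 4 is therefore expected to give about 250 nM, between 120 nM and 520 nM, which is a 1.0-fold higher number from compound 3 to compound 4 (0.02 log units; within the scatter).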

Compound 4, concentration for 50% growth inhibition: 71 nM
The estimate for compound 4 lay 3.5-fold (0.55 log units) above the measured number; measured number outside the range, below it.
By their numbers in this assay, from the lowest: compound 4; then compounds 1, 3 and 2 (each within the scatter of the next, the first and the last beyond it).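

In this assay, the far end of this chain turns out to matter: acetamido in place of ureido gives a 3.4-fold lower number from compound 3 to compound 4 (0.53 log units; beyond the scatter) on a change of a single atom, whereas the earlier swap of end groups stayed within the scatter. The other two compounds also fall behind, with a 5.5-fold lower number from compound 2 to compound 4 (0.74 log units; beyond the scatter) and a 2.7-fold lower number from compound 1 to compound 4 (0.43 log units; beyond the scatter) making compound 4 the strongest inhibitor of growth of the four. Nothing available explains this gain.

On these data alone, it remains open whether a propionamido end, a longer chain carrying the acetamido group, or a plain amine at the chain end would keep this gain.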